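Trimming the methoxyphenyl chalcone: expected cytotoxicity of compound 4

This account rests on a few compounds, and the source may have more. Where it says the series, first, only, none or still open, it means among the compounds named here.

Compound 1 `COC(=O)c1cc(-c2cccc(NC(=O)c3ccc(/C=C/C(=O)c4cc(OC)c(OC)c(OC)c4)cc3)c2)on1` was tested in an ADME assay on Vero cells (Chlorocebus sabaeus) for cytotoxicity, read by MTT assay, with a stated time of 72 h; on this read-out higher numbers stand for lower toxicity in this test and lower numbers for higher toxicity in this test. In this assay compound 1 gives only a limit of the assay, > 50 ug/mL, which is the limit of > 50 ug/mL in this assay, at which 1 of the 3 values shown sits. A second chalcone, compound 2 `CC(C)Cc1ccc(C(=O)/C=C/c2ccc(C(=O)O)cc2)cc1`, also gives only a limit in this assay, < 10 ug/mL, which is the limit of < 10 ug/mL in this assay, at which 1 of the 3 values shown sits. For compound 3 `CCOC(=O)c1nnn(-c2cccc(NC(=O)c3ccc(/C=C/C(=O)c4ccc(Cl)cc4)cc3)c2)c1C` this assay reports "not determined" (no result reported), so no number exists for it. Within the data shown here, compound 1 therefore stands at the upper limit with no number of its own, and since no pair of measured compounds differs in one place, no measured step exists from which the size of a change can be read.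

Compound 4 `COC(=O)c1cc(-c2cccc(NC(=O)c3ccc(/C=C/C(=O)c4ccc(OC)cc4)cc3)c2)on1` differs from compound 1 in one place: 4-methoxyphenyl in place of 3,4,5-trimethoxyphenyl on a carbonyl carbon. The shared core and the amide linkage are kept. The account expects no step beyond the usual scatter in this assay, with compound 4 again at or near the upper limit. The expected value for compound 4 in this assay is 50 ug/mL, estimated between 20 ug/mL and 120 ug/mL. The step this estimate means is expected as a number no higher from compound 1 to compound 4 (the limit leaves the size open).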

Compound 4, half-maximal cytotoxic concentration: > 10 ug/mL
Compound 4: no number, only a limit (the forecaster's own chance of this, stated with the estimate: 60%); the middle value lies beyond the limit too.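

Compound 1 and compound 4 each give only a limit of the assay in this assay, so the step between them cannot be read. The compounds shown leave open whether 4-methoxyphenyl in place of 3,4,5-trimethoxyphenyl on a carbonyl carbon changes the half-maximal cytotoxic concentration, and by how much.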